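The compounds below may be only part of what the source reports. "The series", "measured", "known", "first", "only" and "open" are said of these compounds alone.

Compound 1 `CCOc1ccc(NC2=CC(=O)c3c(nc4n3[C@H]3OC[C@@H](O)[C@H]3OC4)C2=O)cc1`: 14400 nM
Compound 2 `CCc1ccc(NC2=CC(=O)c3nc4n(c3C2=O)[C@H]2OC[C@@H](O)[C@H]2OC4)cc1`: 3990 nM

Among the measured compounds shown here, in a functional assay on HeLa cells (Homo sapiens) for inhibition, read by sulforhodamine B assay (a lower number here means a stronger inhibitor, a higher number a weaker inhibitor), compound 2 stands lowest of the two numbers measured so far, and its nearest neighbour is compound 1, whose number lies beyond the usual scatter above it. Compound 3 `COc1ccccc1NC1=CC(=O)c2nc3n(c2C1=O)[C@H]1OC[C@@H](O)[C@H]1OC3` has not been measured yet. It differs from compound 2 in one place: 2-methoxyphenyl in place of 4-ethylphenyl on an amine nitrogen. For the measured compounds named here, no step between measured compounds matches this change, so the expected step of a 1.6-fold higher number from compound 2 to compound 3 (0.21 log units; within the scatter) is a modest weakening, though a result within the scatter cannot be ruled out. Compound 3 is therefore estimated at 6500 nM, expected between 2000 nM and 22000 nM.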

Compound 3, half-maximal inhibitory concentration: 2950 nM
Compound 3: middle estimate off by 2.2-fold (0.34 log units), on the high side, and the stated range covers the measured number.
By their numbers in this assay, from the lowest: compounds 3 and 2 (each within the scatter of the next); then compound 1.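

In this assay the change to 2-methoxyphenyl in place of 4-ethylphenyl on the amine nitrogen gives a 1.4-fold lower number from compound 2 to compound 3 (0.13 log units; within the scatter) and so leaves the two numbers within the scatter of each other. At this position, then, a group holding a hydrogen-bond acceptor and one holding none read alike in this single pair. No measurement shown here accounts for this result. Still open, from the compounds shown here alone, is how 4-methoxyphenyl would read in this place, and whether an aminophenyl or a carboxyphenyl group on the same nitrogen would stay within the scatter.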